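An Aryl Group Replaces an Alkyl Chain on Weak Inhibitors

This account rests on a few compounds, and the source may have more. Where it says the series, first, only, none or still open, it means among the compounds named here.

Of the compounds shown here, three built on a shared core have been tested in a functional assay on DU-145 cells (Homo sapiens) for inhibition, read by MTT assay, with a stated time of 24 h; a higher number here means a weaker inhibitor, a lower number a stronger inhibitor. Compound 1, `CCCCCCCCn1cc(COC2(C(F)(F)F)Oc3ccccc3C=C2C(=O)OCC)nn1`, gives only a limit of the assay in this assay, > 150000 nM. Compound 2, `O=C(O)C1=Cc2ccccc2OC1(OCc1cc(-c2cccc(C(F)(F)F)c2)no1)C(F)(F)F`, gives 155000 nM in this assay. Compound 3, `CCOC(=O)C1=Cc2ccccc2OC1(OCc1cc(-c2ccc(F)cc2F)no1)C(F)(F)F`, likewise gives only a limit of the assay in this assay, > 150000 nM. Compound 1 therefore stands at the point where most of the data gather, namely (the limit of > 150000 nM in this assay, at which 2 of the 3 values shown sit). Within the data shown here, no two of the measured compounds differ in just one place, so no measured step can be drawn among them; what the three values show together is that none of them reaches a potency that the assay can resolve, with compound 2 sitting at about the same level as the two limits.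

Compound 4, `CCOC(=O)C1=Cc2ccccc2OC1(OCc1cn(-c2cccc(OC)c2)nn1)C(F)(F)F`, has not yet been measured. It differs from compound 1 by 3-methoxyphenyl in place of octyl on an aromatic nitrogen. Among the measured compounds shown here, the measured compounds offer no step that tells how this exchange acts. With the values shown resting at the limit of > 150000 nM in this assay, at which 2 of the 3 values shown sit, the step from compound 1 to compound 4 is expected to stay within the scatter, a step that the limit leaves unreadable from compound 1 to compound 4. Compound 4 is accordingly expected to give 160000 nM in this assay, within a range of 60000 nM to 450000 nM, most likely as another limit rather than a number.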

Compound 4, half-maximal inhibitory concentration: > 150000 nM
Compound 4: a limit, no number; the forecaster's own chance of this, stated with the estimate: 60%; the middle value lies beyond the limit too.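

In this assay compound 4 gives only a limit of the assay, > 150000 nM. Compound 1 also gives only a limit, so no step can be read between compound 1 and compound 4 for 3-methoxyphenyl in place of octyl. The compounds shown leave open whether any change to the shared core gives an inhibitor that this assay can resolve.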